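Growth inhibition notes: from compound 2 to compound 3

The compounds below may be only part of what the source reports. "The series", "measured", "known", "first", "only" and "open" are said of these compounds alone.

For the measured compounds named here, compound 1 `O=C(/C=C/c1cccc([N+](=O)[O-])c1)c1ccccc1` gives 4470 nM in a functional assay on HCT-116 cells (Homo sapiens) for inhibition, read by sulforhodamine B assay, with a stated time of 3 days (a lower number here means a stronger inhibitor of growth, a higher number a weaker inhibitor of growth), the only true number so far. Compound 2 `O=C(/C=C/c1ccc(OCc2ccccc2)cc1)c1ccccc1` reads > 50000 nM, which is a limit of the assay and not a number. This places compound 2 at the limit of > 50000 nM in this assay, at which 1 of the 2 values shown sits. Compound 3 `O=C(/C=C/c1ccc(F)cc1)c1ccccc1` carries fluoro in place of benzyloxy on an aromatic carbon, para to a large group (fluoro in place of benzyloxy on an aromatic carbon). Going by the values given here, no measured pair in this assay isolates this change, so the expected size rests on the two values alone. A step towards stronger growth inhibition, beyond the scatter, is expected: an at least 4.1-fold lower number from compound 2 to compound 3 (0.61 log units; beyond the scatter). With compound 1 at 4470 nM as the only numeric anchor, a result within the measurable range is expected. For compound 3 the estimate is 12000 nM, with an expected range from 3000 nM to 45000 nM.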

Compound 3, concentration for 50% growth inhibition: 4360 nM
Beside the measured number, compound 3's estimate is 2.8-fold (0.44 log units) above it, and the stated range covers the measured number.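

In this assay, for the compounds shown here, fluoro in place of benzyloxy on an aromatic carbon, para to a large group, gives an at least 11-fold lower number from compound 2 to compound 3 (1.05 log units; beyond the scatter) as the first step, and a large one. This position therefore responds strongly to the group it carries, and with fluoro on this carbon compound 3 reads 4360 nM, a true number, so the benzyloxy group with its aromatic ring is not needed for measurable growth inhibition here. Compound 2 reads > 50000 nM, which is a limit of the assay and not a number, so the step has a lower bound and no exact size: the limit of > 50000 nM in this assay, at which 1 of the 3 values shown sits.

The compounds shown leave open whether the gain is tied to fluoro itself or follows from the departure of benzyloxy. A methoxy group or an amine on the same carbon would bear on that question.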